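Swapping acetyl for cyano on the shared core: an estimate

This account rests on a few compounds, and the source may have more. Where it says the series, first, only, none or still open, it means among the compounds named here.

Measured so far:
compound 1, `CC(=O)c1cccc(C#Cc2cc(F)cc(C#N)c2)n1`, gives 240 nM in an in vitro functional assay on HEK293-A cells for agonist activity at metabotropic glutamate receptor 5 (Rattus norvegicus), read by ELISA; a lower number here means a stronger inhibitor, a higher number a weaker inhibitor
compound 2, `CC(=O)c1cccc(C#Cc2cccc(C#N)c2)n1`, gives 300 nM in this assay

Compound 1 gives the lower of the two numbers, but the step of a 1.3-fold higher number from compound 1 to compound 2 (0.10 log units; within the scatter) lies within the scatter, so compound 1 and compound 2 cannot be told apart. Compound 3, `N#Cc1cc(F)cc(C#Cc2cccc(C#N)n2)c1`, is not yet measured. It differs from compound 1 by cyano in place of acetyl on an aromatic carbon. Going by the values given here, the single measured step, a 1.3-fold higher number from compound 1 to compound 2 (0.10 log units; within the scatter), concerns a different change and does not bear on this exchange; nothing measured tests acetyl against cyano. The step of a 1.3-fold higher number from compound 1 to compound 3 (0.10 log units; within the scatter) is therefore expected to stay within the scatter, though with wide uncertainty. The expected value for compound 3 is 300 nM, estimated between 80 nM and 1100 nM.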

Compound 3, half-maximal inhibitory concentration: 9 nM
Compound 3: the middle estimate sits 33-fold (1.52 log units) above what was measured; measured number outside the range, below it.
By their numbers in this assay, from the lowest: compound 3; then compounds 1 and 2 (each within the scatter of the next).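

In this assay, cyano in place of acetyl on the aromatic carbon next to the ring nitrogen gives a 27-fold lower number from compound 1 to compound 3 (1.43 log units; beyond the scatter), so this position is sensitive to the group it carries, whereas the fluoro exchange elsewhere on the shared core stayed within the scatter. Nothing shown accounts for the size of this step. The compounds shown leave open whether an amine, a carboxylic acid or a longer chain at this position would keep so low a number, and whether hydrogen in place of fluoro would matter as little with cyano present as with acetyl.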